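Swapping Thiophen-2-yl for Thiophen-3-yl

A few compounds are considered here, and "the series" means these few. Any claim that something is new, unique, unknown or untested is made for them only; others in the source may bear on it.

In a functional assay on HCT-15 cells (Homo sapiens) for cytotoxicity, read by ELISA, with a stated time of 2 days (a higher number here means a weaker inhibitor, a lower number a stronger inhibitor), compound 1 `Oc1cccc(-c2cc(-c3ccccc3)cc(-c3cccc(O)c3)n2)c1` gives 18400 nM, compound 2 `Oc1cccc(-c2cc(-c3ccccc3)nc(-c3ccccc3)c2)c1` gives 18000 nM and compound 3 `Oc1cccc(-c2cc(-c3ccccc3)nc(-c3cccs3)c2)c1` gives 14100 nM. Compound 3 therefore stands level with the other two, since its values against both lie within the scatter. Compound 4 `Oc1cccc(-c2cc(-c3ccccc3)nc(-c3ccsc3)c2)c1` has the same atoms as compound 3, joined differently, with thiophen-3-yl in place of thiophen-2-yl on an aromatic carbon. The group sits next to the ring nitrogen, meta to a 3-hydroxyphenyl group and meta to a phenyl group.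

Among the compounds with values here, no measured pair compares these two thiophene groups directly. The nearest evidence is the exchange of phenyl for thiophen-2-yl at the same place, a 1.3-fold lower number from compound 2 to compound 3 (0.11 log units; within the scatter), and this step stays within the scatter. Within the data shown here, with that small step as the only guide, and with all three values in this assay so close together, no change beyond the scatter is expected here, and no direction can be favoured. The expected step is a 1.1-fold higher number from compound 3 to compound 4 (0.03 log units; within the scatter), which is no more than the scatter. Compound 4 is estimated at 15000 nM, with an expected range from 8000 nM to 28000 nM.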

Compound 4, half-maximal inhibitory concentration: 24600 nM
The estimate for compound 4 lay 1.6-fold (0.21 log units) below the measured number; the range from low to high includes it.
By their numbers in this assay, from the lowest: compounds 3, 2, 1 and 4 (each within the scatter of the next).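

At this place on the shared core, next to the ring nitrogen, the two thiophene attachments can now be compared directly in this assay: the step is a 1.7-fold higher number from compound 3 to compound 4 (0.24 log units; within the scatter), so the two isomeric groups, with the same atoms joined differently, cannot be told apart in this assay. Thiophen-3-yl also stands level with phenyl, with a step of a 1.4-fold higher number from compound 2 to compound 4 (0.14 log units; within the scatter), which extends what the earlier step of a 1.3-fold lower number from compound 2 to compound 3 (0.11 log units; within the scatter) showed for thiophen-2-yl alone: neither replacing the phenyl ring with a thiophene nor changing the thiophene's point of attachment gives a step beyond the scatter in these compounds. No measurement shown here offers an explanation for the size of these steps.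

On these data alone, only these three aromatic rings appear at this place, so it remains open whether an amine, a carboxylic acid or a longer chain there would give a value clearly apart from the others. Also open, as far as these compounds go, is whether thiophen-3-yl and thiophen-2-yl would stay level if the phenyl group or the 3-hydroxyphenyl group on the core were replaced.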